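A few compounds are considered here, and "the series" means these few. Any claim that something is new, unique, unknown or untested is made for them only; others in the source may bear on it.

Measured so far in a functional assay on HeLa cells (Homo sapiens) for cytotoxicity, read by WST assay, with a stated time of 48 h; a higher number here means a weaker inhibitor, a lower number a stronger inhibitor:
compound 1 `Cc1ccc(/C=C/C[C@H]2C[C@@H]([C@@H](O)c3ccccc3)CO[C@@H]2c2ccccc2)cc1C` gives 10000 nM
compound 2 `O[C@@H](c1ccccc1)[C@H]1CO[C@H](c2ccccc2)[C@@H](C/C=C/C2CCCCC2)C1` gives 6440 nM

Among the measured compounds shown here, compound 2 has the lowest of the two numbers in this assay; its nearest neighbour is compound 1, and the only step between them, a 1.6-fold lower number from compound 1 to compound 2 (0.19 log units; within the scatter), lies within the scatter, so no order between the two can be read from these values.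

Compound 3 `Oc1ccc(/C=C/C[C@H]2C[C@@H]([C@@H](O)c3ccccc3)CO[C@@H]2c2ccccc2)cc1` is not yet measured. It differs from compound 2 in one place: 4-hydroxyphenyl in place of cyclohexyl on a double-bonded chain carbon bound to a double-bonded chain carbon

For the measured compounds named here, the one measured step that bears on this change is a 1.6-fold lower number from compound 1 to compound 2 (0.19 log units; within the scatter), where a six-membered aromatic ring of carbon only was exchanged for cyclohexyl at the same place and the number stayed within the scatter. Going by the values given here, compound 3 takes the reverse direction, and the entering group adds one hydrogen-bond donor and one hydrogen-bond acceptor that neither measured compound shows at that place; no measured pair tests such an addition. On the two numbers available, the expected step for compound 3 in this assay is a 1.2-fold higher number from compound 2 to compound 3 (0.09 log units; within the scatter), nothing beyond the scatter in either direction. Compound 3 is therefore estimated at 8000 nM, with a range from 3000 nM to 25000 nM.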

Compound 3, half-maximal inhibitory concentration: 14400 nM
Beside the measured number, compound 3's estimate is 1.8-fold (0.26 log units) below it, and the stated range covers the measured number.
By their numbers in this assay, from the lowest: compounds 2, 1 and 3 (each within the scatter of the next, the first and the last beyond it).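

In this assay, among the compounds shown here, the exchange of cyclohexyl for 4-hydroxyphenyl on a double-bonded chain carbon bound to a double-bonded chain carbon gives a 2.2-fold higher number from compound 2 to compound 3 (0.35 log units; beyond the scatter) and is the first step to pass the scatter, so the group at this place can move the number, though only modestly. For the compounds shown here, the two aryl groups do not separate: the exchange of 3,4-dimethylphenyl for 4-hydroxyphenyl gives a 1.4-fold higher number from compound 1 to compound 3 (0.16 log units; within the scatter) and leaves no order between those compounds, while compound 1 also stays within the scatter of compound 2, which goes against any simple split of aromatic from non-aromatic groups at this place. No measurement offers an explanation for the step from cyclohexyl to 4-hydroxyphenyl.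

The compounds shown leave open whether the hydroxyl or the aromatic ring carries that step, a question that the unsubstituted phenyl group would address directly. Also open, as far as these compounds go, is whether an amine, a carboxylic acid or a longer chain at this place would move the number further in either direction.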